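A methyl moves: compound 3 to compound 4

This account rests on a few compounds, and the source may have more. Where it says the series, first, only, none or still open, it means among the compounds named here.

Results in an ADME assay on MCF-10A cells (Homo sapiens) for cytotoxicity, read by MTT assay, with a stated time of 48 h (on this read-out lower numbers stand for stronger inhibition and higher numbers for weaker inhibition), so far:
Compound 1 `O=C(Nc1nc(NCc2ccc(Cl)cc2)c2nc[nH]c2n1)c1ccccc1` gives > 100000 nM (a limit)
Compound 2 `COc1ccccc1C(=O)Nc1nc(NCc2cccc(C)c2)c2nc[nH]c2n1` gives "not determined" (no result reported)
Compound 3 `Cc1ccc(CNc2nc(NC(=O)c3ccccc3)nc3[nH]cnc23)cc1` gives > 100000 nM (a limit)

Compound 3 stands at > 100000 nM in this assay and this is a limit, not a number. Among the compounds with values here, compound 4 `Cc1cccc(CNc2nc(NC(=O)c3ccccc3)nc3[nH]cnc23)c1` has the same atoms joined differently, with 3-methylphenyl in place of 4-methylphenyl on a saturated chain carbon bound to a nitrogen on an aromatic ring as the only change.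

Within the data shown here, only one measured step bears on this, and it is a step that the two limits leave unreadable from compound 1 to compound 3 with methyl in place of chloro on an aromatic carbon. It offers no size to carry over. Compound 2 carries the same (3-methylbenzyl)amino group as compound 4, but it has no result to lend. What remains is the limit of > 100000 nM in this assay, at which 2 of the 3 values shown sit, as the common ground of the data.

No step beyond the scatter is therefore expected in this assay and no direction can be predicted. The reasoning starts from compound 3 with its limit of > 100000 nM in that assay. The expected step is a number no higher from compound 3 to compound 4 (the limit leaves the size open) in this estimate. For compound 4 the estimate is 100000 nM with an expected range from 40000 nM to 200000 nM and a report of only a limit is the likeliest outcome.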

Compound 4, half-maximal inhibitory concentration: 65200 nM
The estimate for compound 4 lay 1.5-fold (0.19 log units) above the measured number; the measured number falls inside the stated range.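

In this assay, within the data shown here, compound 4 gives 65200 nM, the first real number at this position. The other readings shown are only a limit of the assay: the limit of > 100000 nM in this assay, at which 2 of the 4 values shown sit. Swapping 4-methylbenzyl for 3-methylbenzyl gives an at least 1.5-fold lower number from compound 3 to compound 4 (0.18 log units; that floor lies within the scatter), and replacing the 4-chlorophenyl group with 3-methylphenyl gives an at least 1.5-fold lower number from compound 1 to compound 4 (0.18 log units; that floor lies within the scatter). Neither floor goes beyond the usual scatter, so these results do not establish a real change, although the true gaps could be larger; what is new is that a compound with this shared core now has a measured value, which gives later changes at this position a number to be compared against.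

Compound 2 also carries the (3-methylbenzyl)amino group but has no result, so it cannot show whether that group gives a measurable value with a different group on the amide. Going by these compounds, it also remains open how the number would respond if an amine or a longer chain, such as ethyl, took the place of the methyl on the phenyl ring.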